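A few compounds are considered here, and "the series" means these few. Any claim that something is new, unique, unknown or untested is made for them only; others in the source may bear on it.

Compound 1 `Cc1c(C(=O)NCc2cccc(C(F)(F)F)c2)cnn1-c1ccc(F)cc1`: 790 nM
Compound 2 `Cc1c(C(=O)NCc2cccc(C(F)(F)F)c2)cnn1-c1ccccc1Cl`: > 3000 nM

Both compounds share one core and differ only in the group on an aromatic nitrogen. In a functional assay on cells for antagonist activity at C-C chemokine receptor type 1 (Homo sapiens), read by FLIPR and calcium flux (a higher number here means a weaker inhibitor, a lower number a stronger inhibitor), compound 1 gives 790 nM. In this assay compound 2 gives only a limit, > 3000 nM, so no number is known for it; it sits at the limit of > 3000 nM in this assay, at which 1 of the 2 values shown sits. Among the compounds with values here, the single measured step, an at least 3.7-fold higher number from compound 1 to compound 2 (0.57 log units; beyond the scatter), shows a weakening. Compound 3 `Cc1c(C(=O)NCc2cccc(C(F)(F)F)c2)cnn1Cc1ccccc1` carries benzyl in place of 2-chlorophenyl on an aromatic nitrogen. Within the data shown here, no measured step covers a swap of an aryl group for a benzyl group on this nitrogen, so the measured step of an at least 3.7-fold higher number from compound 1 to compound 2 (0.57 log units; beyond the scatter) only tells where the starting point lies, and the direction of the new change is open. Compound 3 is expected to stay in a similar weak region, the expected step of an at least 1.2-fold lower number from compound 2 to compound 3 (0.07 log units; that floor lies within the scatter) being small and uncertain. Compound 3 is estimated at 2500 nM, with a range from 500 nM to 8000 nM in this assay.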

Compound 3, half-maximal inhibitory concentration: > 3000 nM
Compound 3: only a limit was reported; the forecaster's own chance of this, stated with the estimate: 45%; at least 1.2-fold (0.07 log units) between middle value and limit.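

Within the data shown here, the one readable comparison for benzyl on this nitrogen is against 4-fluorophenyl, and it gives an at least 3.7-fold higher number from compound 1 to compound 3 (0.57 log units; beyond the scatter). Two different replacements of 4-fluorophenyl, 2-chlorophenyl and benzyl, therefore both weaken inhibition, and of the three groups shown only 4-fluorophenyl gives an actual number in this assay. The step from compound 2 to compound 3 cannot be read, since both results are limits and not numbers, so these two groups cannot be ranked: the limit of > 3000 nM in this assay, at which 2 of the 3 values shown sit.

As far as these compounds go, how far past the limit compound 2 and compound 3 really lie remains open. Also open, from the compounds shown here alone, is whether another group on this nitrogen, such as 4-chlorophenyl, a pyridine ring or the longer 2-phenylethyl chain, would match or improve on 4-fluorophenyl.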